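This account rests on a few compounds, and the source may have more. Where it says the series, first, only, none or still open, it means among the compounds named here.

Measured compounds:
compound 1, `COc1ccc(N2CCN(C(=S)N/N=C3\C(=O)Nc4ccc(Cl)cc43)CC2)cc1` — 7740 nM
compound 2, `O=C1Nc2ccc(Cl)cc2/C1=N/NC(=S)N1CCN(c2ccccc2Cl)CC1` — 4910 nM
compound 3, `O=C1Nc2ccc(Cl)cc2/C1=N/NC(=S)N1CCN(c2ccc([N+](=O)[O-])cc2)CC1` — 12000 nM

All three share the same core and differ only in the aryl group on the amine nitrogen in the ring, read in a functional assay on HCT-116 cells (Homo sapiens) for inhibition, read by MTT assay, with a stated time of 72 h; on this read-out higher numbers stand for weaker inhibition and lower numbers for stronger inhibition. Compound 3 gives the highest number of the three: against compound 1 the gap is a 1.6-fold higher number from compound 1 to compound 3 (0.19 log units; within the scatter), against compound 2 it is a 2.4-fold higher number from compound 2 to compound 3 (0.39 log units; beyond the scatter).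

Compound 4, `O=C1Nc2ccc(Cl)cc2/C1=N/NC(=S)N1CCN(c2ccccc2[N+](=O)[O-])CC1`, is not yet measured. Relative to compound 3 the change is 2-nitrophenyl in place of 4-nitrophenyl on an amine nitrogen in a ring: the same atoms, joined differently.

Among the measured compounds shown here, no measured step moves a group around the same ring, so the bearing of the existing steps is indirect. The step of a 1.6-fold lower number from compound 1 to compound 2 (0.20 log units; within the scatter) shows a change of substituent and position together landing within the scatter; the step of a 2.4-fold higher number from compound 2 to compound 3 (0.39 log units; beyond the scatter) is the only one beyond the scatter and places the 4-nitrophenyl compound at the weak end. On this basis a small shift, if any, is expected for compound 4 in this assay, most likely toward a lower number, a 1.5-fold lower number from compound 3 to compound 4 (0.18 log units; within the scatter). The estimated value for compound 4 is 8000 nM, with a range from 3500 nM to 18000 nM.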

Compound 4, half-maximal inhibitory concentration: 4570 nM
Beside the measured number, compound 4's estimate is 1.8-fold (0.24 log units) above it, and the stated range covers the measured number.
By their numbers in this assay, from the lowest: compounds 4, 2, 1 and 3 (each within the scatter of the next, the first and the last beyond it).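

In this assay, the step from 4-nitrophenyl to 2-nitrophenyl on the amine nitrogen in the ring is the only one shown that keeps the same atoms and changes only how they are joined, and it lies beyond the scatter (a 2.6-fold lower number from compound 3 to compound 4 (0.42 log units; beyond the scatter)). The high number of compound 3 therefore belongs to 4-nitrophenyl and not to the nitro group as such. Compound 4 does not separate from the other two aryl compounds, either with nitro in place of chloro on an aromatic carbon (a 1.1-fold lower number from compound 2 to compound 4 (0.03 log units; within the scatter)) or with 2-nitrophenyl in place of 4-methoxyphenyl (a 1.7-fold lower number from compound 1 to compound 4 (0.23 log units; within the scatter)).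

Nothing on hand accounts for the gap between the two nitrophenyl compounds. Going by these compounds, whether an amine or a carboxylic acid in place of nitro on the aromatic carbon would shift the number remains open.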